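The compounds below may be only part of what the source reports. "The series", "measured", "known", "first", "only" and "open" are said of these compounds alone.

Measured compounds

Compound 1 `CC1=CC[C@H]2[C@H](CC[C@]2(C)O)C(C)(C)[C@@H]1CC[C@H]1[C@]2(C)CC[C@H](OC(=O)c3ccncc3)C(C)(C)O[C@H]2CC[C@@]1(C)O` gives 25300 nM in a functional assay on MCF7 cells (Homo sapiens) for antiproliferative activity, read by MTT assay, with a stated time of 72 h; on this read-out higher numbers stand for weaker inhibition and lower numbers for stronger inhibition.
Compound 2 `CC1=CC[C@H]2[C@@H]1CC=C(C)[C@@H](CC[C@H]1[C@]3(C)CC[C@H](OC(=O)CCC(=O)O)C(C)(C)O[C@H]3CC[C@@]1(C)O)C2(C)C` gives no number in this assay, only a limit of the assay: > 50000 nM.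

Going by the values given here, compound 1 thus holds the only numerical value in this assay; the other entry is a limit, (the limit of > 50000 nM in this assay, at which 1 of the 2 values shown sits), so compound 1 cannot be ranked against compound 2 beyond the fact that compound 2 could not be quantified.

Compound 3 `CC1=CC[C@H]2[C@H](CC[C@]2(C)O)C(C)(C)[C@@H]1CC[C@H]1[C@]2(C)CC[C@H](OC(=O)c3ccc(C(F)(F)F)c(F)c3)C(C)(C)O[C@H]2CC[C@@]1(C)O` has not yet been measured in this assay. It differs from compound 1 in a single place:

3-fluoro-4-(trifluoromethyl)phenyl in place of pyridin-4-yl on a carbonyl carbon

Among the compounds with values here, no pair of measured compounds differing in one place is available, so the effect of exchanging the aryl group on the ester carbonyl cannot be read from the data themselves. With compound 1 sitting at 25300 nM and nothing to suggest that the ester aryl group drives potency, the expected step in this assay is a 1.2-fold lower number from compound 1 to compound 3 (0.06 log units; within the scatter), that is, nothing beyond the usual scatter. Compound 3 is accordingly estimated at 22000 nM, with a plausible range from 6000 nM to 60000 nM.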

Compound 3, half-maximal inhibitory concentration: > 50000 nM
Compound 3: a limit, no number; the forecaster's own chance of this, stated with the estimate: 25%; middle value at least 2.2-fold (0.35 log units) from the limit.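

Going by these compounds alone, on the carbonyl carbon of the ester, the exchange of pyridin-4-yl for 3-fluoro-4-(trifluoromethyl)phenyl gives the only step that can be read in this assay: an at least 1.9-fold higher number from compound 1 to compound 3 (0.29 log units; that floor lies within the scatter). In this assay compound 3 gives > 50000 nM, which is a limit of the assay and not a number, so this step has a floor but no measured size, and that floor alone does not establish a real loss. The position therefore shows no gain from this exchange, and only the pyridin-4-yl ester keeps a numerical value, but the limit of the assay conceals how large the change may be: the limit of > 50000 nM in this assay, at which 2 of the 3 values shown sit.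

The compounds shown leave open how far compound 3 actually lies from compound 1, and whether the ring nitrogen or the fluorine and trifluoromethyl substituents account for the difference. They also leave open whether a plain phenyl, a pyridin-3-yl or an aminophenyl group on the same carbonyl carbon would give a number in this assay.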